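This account rests on a few compounds, and the source may have more. Where it says the series, first, only, none or still open, it means among the compounds named here.

Measured compounds:
- compound 1, `CN(C)CCN(CCN(C)C)c1cccc(C(=O)N2CCc3ccc(OS(N)(=O)=O)cc3C2)c1`: 17.1%
- compound 2, `CCN(Cc1ccccn1)c1ccc(C(=O)N2CCc3ccc(OS(N)(=O)=O)cc3C2)cc1`: 87.7%
- compound 3, `CCN(Cc1ccccc1)c1ccc(C(=O)N2CCc3ccc(OS(N)(=O)=O)cc3C2)cc1`: 83.6%

All three were tested in an assay on HEK293 cells for inhibition of Steryl-sulfatase (Homo sapiens), tested at 1 uM; on this read-out higher numbers stand for a stronger effect at the one concentration tested and lower numbers for a weaker effect. Compound 1 stands lowest of the three numbers; compound 3 is the nearest to it and compound 2 the furthest, both far beyond the scatter. The unmeasured compound 4, `CCN(Cc1cccc(Br)c1)c1cccc(C(=O)N2CCc3ccc(OS(N)(=O)=O)cc3C2)c1`, is reached from compound 1 by one change: (3-bromobenzyl)(ethyl)amino in place of bis(2-(dimethylamino)ethyl)amino on an aromatic carbon.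

Among the measured compounds shown here, only one measured step is known, and it touches the new group indirectly: a number 4.1 percentage points lower from compound 2 to compound 3 (within the scatter), so phenyl and pyridin-2-yl on that chain carbon behave alike. For the measured compounds named here, no measured step covers the exchange of bis(2-(dimethylamino)ethyl)amino for a group that carries a phenyl on a saturated chain carbon bound to the aromatic nitrogen, but the values of compound 1 and compound 3 show that the two kinds of substituent sit far apart in this assay. A large rise is therefore expected; compound 4 carries the group at a different place on the ring than compound 3, so the estimate is kept wide. Compound 4 is expected to give 68%, between 40% and 90%, which is the expected step of a number 50.9 percentage points higher from compound 1 to compound 4 (beyond the scatter).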

Compound 4, a percentage reported as inhibition, at one concentration (the size of the read-out at that concentration, not a potency): 24.9%
The estimate for compound 4 lay 43.1 percentage points above the measured number; measured number outside the range, below it.
By their numbers in this assay, from the lowest: compounds 1 and 4 (each within the scatter of the next); then compounds 3 and 2 (each within the scatter of the next).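

In this assay, placing (3-bromobenzyl)(ethyl)amino instead of bis(2-(dimethylamino)ethyl)amino on this aromatic carbon, meta to a large group, gives a number 7.8 percentage points higher from compound 1 to compound 4 (within the scatter), so the two groups cannot be told apart at this place. The earlier compounds shown here did not show that a group carrying a six-membered aromatic ring of carbon only can sit here without a read-out beyond the scatter of that of compound 1. No measurement at hand gives a reason for this result.

Compound 3 and compound 4 differ in more than one place, so the part played by the bromine cannot be separated from that of the place on the ring. On these data alone, how (benzyl)(ethyl)amino without the bromine reads on this same aromatic carbon remains open, as does the reading of the bromine-carrying group at the place it occupies in compound 3.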